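Moving one chlorine around a phenyl ring

This account rests on a few compounds, and the source may have more. Where it says the series, first, only, none or still open, it means among the compounds named here.

Compound 1 `COc1ccc(/C=C2\CCC/C(=C\c3cccc(OC)c3OC)C2=O)cc1`: 16300 nM
Compound 2 `COc1cc(/C=C2\CCC/C(=C\c3cccc(OC)c3OC)C2=O)cc(OC)c1`: 4500 nM
Compound 3 `COc1ccc(/C=C2\CCC/C(=C\c3ccccc3Cl)C2=O)cc1OC`: 6800 nM

These three compounds were tested in a functional assay on HT-1080 cells (Homo sapiens) for cytotoxicity, read by MTT assay, with a stated time of 72 h; a higher number here means a weaker inhibitor, a lower number a stronger inhibitor. Compound 3 at 6800 nM cannot be told apart from compound 2 at 4500 nM, since their values lie within the usual scatter of repeated measurements. Compound 1 at 16300 nM gives a higher number than compound 3, and that gap lies beyond the scatter.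

The next compound to be measured is compound 4 `COc1ccc(/C=C2\CCC/C(=C\c3ccc(Cl)cc3)C2=O)cc1OC`. It carries 4-chlorophenyl in place of 2-chlorophenyl on a double-bonded chain carbon bound to a double-bonded ring carbon. The two compounds have the same atoms, joined differently.

Going by the values given here, no two measured compounds differ in only one place, so the data do not show directly what such a change does. The expectation therefore rests on the closest relative, compound 3 at 6800 nM, and the range is kept wide. The expected move in this assay is a 1.1-fold lower number from compound 3 to compound 4 (0.05 log units; within the scatter), which means no change beyond the scatter. Compound 4 is estimated at 6000 nM, with an expected range of 2000 nM to 18000 nM.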

Compound 4, half-maximal inhibitory concentration: 4800 nM
Compound 4: middle estimate off by 1.3-fold (0.10 log units), on the high side; measured number inside the range.
By their numbers in this assay, from the lowest: compounds 2, 4 and 3 (each within the scatter of the next); then compound 1.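

Going by these compounds alone, this is the first pair in the set that differs in only one place, so it gives a direct reading of 4-chlorophenyl in place of 2-chlorophenyl on a double-bonded chain carbon bound to a double-bonded ring carbon. In this assay the change gives a 1.4-fold lower number from compound 3 to compound 4 (0.15 log units; within the scatter), so the two compounds cannot be told apart, even though their atoms are joined differently. For this pair, then, the place of the chlorine on the phenyl ring leaves no mark that this measurement can detect, and nothing here offers a measured reason for that.

This reading rests on a single pair, so it cannot say whether the place of the chlorine would also make no detectable difference on a shared core carrying other groups. It also leaves open whether this phenyl ring tolerates a real change of group rather than a shift of the same one, for example an amine or a carboxylic acid in place of the chlorine.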